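Straightening the side chain of compound 2

A few compounds are considered here, and "the series" means these few. Any claim that something is new, unique, unknown or untested is made for them only; others in the source may bear on it.

Measured so far in a functional assay on the whole organism (stomach) for inhibition, with Rattus norvegicus as the target, at a dose of 100 mg/kg by the intraduodenal route; on this read-out lower numbers stand for less inhibition and higher numbers for more inhibition at the one dose given (going by the name of the read-out):
compound 1 `CC1=NN(CC(C)C(=N)S)C(=O)CC1`: 15.6%
compound 2 `CC(CN1N=C(c2ccccc2)CCC1=O)C(=N)S`: 28.2%
compound 3 `Cc1ccc(=O)n(CCC(=N)S)n1`: 73.9%

Compound 2 stands second highest of these three numbers. Going by the values given here, its nearest neighbour is compound 1, and the only step measured between two compounds is a number 12.6 percentage points higher from compound 1 to compound 2 (beyond the scatter), a change on the ring rather than on the side chain. Compound 3 lies furthest away, with a different core.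

Compound 4 `N=C(S)CCCN1N=C(c2ccccc2)CCC1=O` differs from compound 2 by a group of 5 heavy atoms (3 carbon, 1 nitrogen, 1 sulfur; no ring) in place of a group of 5 heavy atoms (3 carbon, 1 nitrogen, 1 sulfur; no ring), on a saturated chain carbon bound to an amide-type nitrogen in a ring. The two share all their atoms, only joined differently. Among the compounds with values here, no measured pair changes this chain, so the measured step gives no guidance, and no step beyond the scatter is expected in this assay. Compound 4 is therefore expected to give about 30%, within 10% to 55%. The step this expectation means is a number 1.8 percentage points higher from compound 2 to compound 4 (within the scatter).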

Compound 4, a percentage reported as inhibition, in the whole organism at one dose (the size of the read-out at that dose, not a potency): 50.3%
Compound 4: middle estimate off by 20.3 percentage points, on the low side; measured number inside the range.
By their numbers in this assay, from the lowest: compound 1; then compound 2; then compound 4; then compound 3.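

Joining the same atoms differently is enough to shift the result in this assay: the change gives a number 22.1 percentage points higher from compound 2 to compound 4 (beyond the scatter), with no atom gained or lost. Going by these compounds alone, the earlier step came from a change on the ring, so this is the first sign that the arrangement of the side chain itself matters for the number on this core. No measurement here explains the rise.

Still open, going by these compounds, is whether a longer chain, or a carboxylic acid in place of this group, would read higher or lower on the core of compound 4.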